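The source may hold more compounds than are shown below. What is called first, only, known or untested is meant among the compounds shown, and "the series" means these compounds.

In an assay on HEK293 cells for positive allosteric modulation of metabotropic glutamate receptor 5 (Homo sapiens), read by FLIPR, with a stated time of 1 h (on this read-out lower numbers stand for an effect already at smaller amounts and higher numbers for an effect only at larger amounts of compound), the two measured compounds gave:

Compound 1 `O=C(C1CCCC1)N1CCc2nc(C#Cc3ccccc3)sc2C1`: 19 nM
Compound 2 `O=C(c1cccc(Cl)c1)N1CCc2nc(C#Cc3ccccc3)sc2C1`: 8.7 nM

Compound 2 stands at the lower of these two numbers, and compound 1 at a higher one. Going by the values given here, the only measured step, a 2.2-fold lower number from compound 1 to compound 2 (0.34 log units; beyond the scatter), replaced the whole group on the carbonyl carbon and so says nothing directly about a small swap on the aromatic ring. Compound 3 `N#Cc1cccc(C(=O)N2CCc3nc(C#Cc4ccccc4)sc3C2)c1` differs from compound 2 by cyano in place of chloro on an aromatic carbon. Among the compounds with values here, with no matching precedent, compound 3 is expected to stay close to compound 2, a step of a 1.4-fold higher number from compound 2 to compound 3 (0.14 log units; within the scatter) in this assay. The estimate for compound 3 is 12 nM, within a range from 4 nM to 40 nM.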

Compound 3, half-maximal effective concentration: 71 nM
Compound 3: middle estimate off by 5.9-fold (0.77 log units), on the low side; the whole stated range lies below it.
By their numbers in this assay, from the lowest: compound 2; then compound 1; then compound 3.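

On this aromatic carbon the choice of small group matters: in this assay, cyano in place of chloro gives an 8.2-fold higher number from compound 2 to compound 3 (0.91 log units; beyond the scatter) and so is not a neutral swap. Replacing cyclopentyl with 3-cyanophenyl gives a 3.7-fold higher number from compound 1 to compound 3 (0.57 log units; beyond the scatter) in the opposite direction from the 3-chlorophenyl step, so an aromatic ring on the carbonyl carbon does not by itself bring a lower number. No measurement shown here accounts for this change.

Going by these compounds, whether a fluoro, methyl or methoxy group here would stay close to chloro or move toward cyano remains open. So does how chloro and cyano compare elsewhere on this ring.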